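Swapping an aryl for a cinnamyl group on the piperazine

This account rests on a few compounds, and the source may have more. Where it says the series, first, only, none or still open, it means among the compounds named here.

Compound 1 `N#Cc1ccc(OCC(O)CN2CCN(c3ccccn3)CC2)cc1` gives 39.6% in a functional assay on the whole organism (blood) with Rattus norvegicus as the target, at a dose of 100 mg/kg by the oral route; a lower number here means less inhibition, a higher number more inhibition at the dose given (going by the name of the read-out). Compound 2 `COc1ccc(N2CCN(CC(O)COc3ccc(Cl)cc3)CC2)cc1` gives 4.6% in this assay, the lower of the two numbers, with compound 1 standing higher by more than the usual scatter. From the compounds shown here alone, compound 3 `OC(COc1ccc(Cl)cc1)CN1CCN(C/C=C/c2ccccc2)CC1` is untested; it differs from compound 2 by 3-phenylprop-2-en-1-yl in place of 4-methoxyphenyl on an amine nitrogen in a ring. Among the compounds with values here, no measured pair shows what such a change does, so the step of a number 17.4 percentage points higher from compound 2 to compound 3 (beyond the scatter) is only an expectation: a moderate rise, likely beyond the scatter. Compound 3 is accordingly estimated at 22%, within a range from 2% to 50%.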

Compound 3, a percentage reported as inhibition, in the whole organism at one dose (the size of the read-out at that dose, not a potency): 14.6%
Estimate against measurement, compound 3: 7.4 percentage points above, within the range that was stated.
By their numbers in this assay, from the lowest: compounds 2 and 3 (each within the scatter of the next); then compound 1.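

With 3-phenylprop-2-en-1-yl in place of 4-methoxyphenyl on an amine nitrogen in a ring, this assay shows a number 10 percentage points higher from compound 2 to compound 3 (within the scatter). At this position, the two groups therefore cannot be told apart, even though one brings a double bond outside aromatic rings and loses the hydrogen-bond acceptor of the other. Nothing available explains this result. Still open, from the compounds shown here alone, is whether a benzyl group or a saturated 3-phenylpropyl chain on this nitrogen would also read the same. Whether a group without any aromatic ring, such as a plain methyl, would do so is open too.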